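Chain-end variation on the shared core: from compound 3 to 4

This account rests on a few compounds, and the source may have more. Where it says the series, first, only, none or still open, it means among the compounds named here.

All members share one core and differ only at the end of the chain. In a functional assay on MCF7 cells (Homo sapiens) for cytotoxicity, read by MTT assay, with a stated time of 48 h (on this read-out higher numbers stand for weaker inhibition and lower numbers for stronger inhibition), compound 1 `C=CC(C)(O)CC[C@@H]1C(=C)CC[C@H](Br)[C@@]1(C)CCC(O)C(C)(C)Cl` gives 71500 nM. Compound 2 `C=CC(C)(O)CC[C@@H]1C(=C)CC[C@H](Br)[C@@]1(C)CCC(Br)C(C)(C)O` gives > 100000 nM; 60700 nM (2 entries) in this assay, as the several entries of compound 2 in this assay, > 100000 nM; 60700 nM (2 entries) shows. Compound 3 `C=CC(C)(O)CC[C@@H]1C(=C)CC[C@H](Br)[C@@]1(C)CCC(OC)C(C)(C)O` reaches only a limit in this assay, > 100000 nM, so no single number stands for it. Within the data shown here, the single measured step, an at least 1.3-fold higher number from compound 1 to compound 3 (0.14 log units; that floor lies within the scatter), lies within the scatter, and with the limit of > 100000 nM in this assay, at which 1 of the 3 values shown sits, it marks the whole set as weak. Compound 4 `C=CC(C)(O)CC[C@@H]1C(=C)CC[C@H](Br)[C@@]1(C)CCC(O)C(=C)C` carries the change (1-hydroxy-2-methylprop-2-en-1-yl in place of 2-hydroxy-1-methoxy-2-methylpropyl on a saturated chain carbon, two bonds along the chain from a saturated ring carbon). Among the measured compounds shown here, no measured step touches this group and the one step seen is flat, so no movement beyond the scatter is expected: an at least 1.2-fold lower number from compound 3 to compound 4 (0.09 log units; that floor lies within the scatter). Compound 4 is therefore estimated at 80000 nM, with a range of 30000 nM to 200000 nM.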

Compound 4, half-maximal inhibitory concentration: > 100000 nM
Compound 4 gave a limit, no number (the forecaster's own chance of this, stated with the estimate: 45%); middle value at least 1.2-fold (0.09 log units) from the limit.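

In this assay, compound 4 stands at a limit, > 100000 nM, so a chain end with a double bond and no halogen or methoxy also yields no single number, and the limit now holds more of the set: the limit of > 100000 nM in this assay, at which 2 of the 4 values shown sit. With 1-methylethenyl in place of 1-chloro-1-methylethyl, the record shows an at least 1.3-fold higher number from compound 1 to compound 4 (0.14 log units; that floor lies within the scatter), so this change gives no stronger inhibition. The step between compound 3 and compound 4 cannot be read, since both values are limits. On these data alone, whether an amine or a carboxylic acid at this chain end would give a stronger value in this assay remains open.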